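Swapping bromo for nitro on the pendant phenyl ring

A few compounds are considered here, and "the series" means these few. Any claim that something is new, unique, unknown or untested is made for them only; others in the source may bear on it.

Of the compounds shown here, three that share one core have been measured in a functional assay on MCF7 cells (Homo sapiens) for inhibition, read by sulforhodamine B assay, with a stated time of 72 h; on this read-out higher numbers stand for weaker inhibition and lower numbers for stronger inhibition. Compound 1 `CC(c1ccc(-c2ccccc2)c(F)c1)c1nnc2n1N=C(c1ccc(OC(F)(F)F)cc1)CS2` gives 4800 nM. Compound 2 `CC(c1ccc(-c2ccccc2)c(F)c1)c1nnc2n1N=C(c1ccc(Cl)cc1)CS2` gives 8700 nM, and compound 3 `CC(c1ccc(-c2ccccc2)c(F)c1)c1nnc2n1N=C(c1ccc(Br)cc1)CS2` gives 7400 nM. Compound 3 sits second highest of the three numbers, with compound 2 nearest and compound 1 furthest, and all three values lie within the usual scatter of one another, so none can be called stronger or weaker than the rest.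

Compound 4 `CC(c1ccc(-c2ccccc2)c(F)c1)c1nnc2n1N=C(c1ccc([N+](=O)[O-])cc1)CS2` has not yet been measured. It differs from compound 3 in one place: nitro in place of bromo on an aromatic carbon. The earlier steps shown here that bear on this are the other exchanges at the same aromatic carbon: a 1.8-fold higher number from compound 1 to compound 2 (0.26 log units; within the scatter), a 1.5-fold higher number from compound 1 to compound 3 (0.19 log units; within the scatter) and a 1.2-fold lower number from compound 2 to compound 3 (0.07 log units; within the scatter). Each of these replaced the group on that carbon without moving the number beyond the scatter. None of them involved a nitro group, so the new exchange is not covered directly, but what has been seen so far gives no reason to expect a large move in this assay in either direction.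

For compound 4 the expected step is a 1.1-fold lower number from compound 3 to compound 4 (0.02 log units; within the scatter), a move that stays within the scatter. The estimate for compound 4 is 7000 nM, with a range from 2500 nM to 20000 nM.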

Compound 4, half-maximal inhibitory concentration: 7800 nM
Compound 4: middle estimate off by 1.1-fold (0.05 log units), on the low side; the range from low to high includes it.
By their numbers in this assay, from the lowest: compounds 1, 3, 4 and 2 (each within the scatter of the next).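

In this assay, exchanging 4-bromophenyl for 4-nitrophenyl gives a 1.1-fold higher number from compound 3 to compound 4 (0.02 log units; within the scatter) even though the group grows from one heavy atom to three and gains two hydrogen-bond acceptors, so this larger change in the counted make-up of the group produces no readable difference. Nitro also reads level with the other two groups, with a 1.1-fold lower number from compound 2 to compound 4 (0.05 log units; within the scatter) against chloro and a 1.6-fold higher number from compound 1 to compound 4 (0.21 log units; within the scatter) against trifluoromethoxy. This aromatic carbon, para to a large group, has now carried four different groups without any step leaving the scatter, and nothing measured here explains why they read alike.

As far as these compounds go, whether this tolerance extends to other kinds of group remains open, for example an amine, a carboxylic acid or a longer chain such as butoxy on the same carbon. The compounds shown also vary only this one carbon, so they cannot tell whether the number in this assay would respond to changes elsewhere on the shared core.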